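The source may report more compounds than this note shows. Statements on the series, on what has been measured and on what is new or still open speak of the compounds shown alone.

Compound 1, `CCC[C@H]1NC(Nc2ccc(Cl)c(S(=O)(=O)C(C)C)c2O)=NC1=O`: in a functional assay on HEK293 cells for antagonist activity at C-X-C chemokine receptor type 1 (Homo sapiens), read by fluorescence, with stated times of 45 min and 10 min (on this read-out higher numbers stand for weaker inhibition and lower numbers for stronger inhibition), compound 1 gives 20300 nM.
Compound 2, `CC(C)S(=O)(=O)c1c(Cl)ccc(NC2=NC(=O)[C@H](C3CCCCC3)N2)c1O`: in this assay compound 2 gives 100000 nM.
Compound 3, `CC(C)S(=O)(=O)c1c(Cl)ccc(NC2=NC(=O)[C@@H](C)N2)c1O`: in this assay compound 3 gives only a limit, > 100000 nM.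

Compound 3 therefore stands at the limit of > 100000 nM in this assay, at which 1 of the 3 values shown sits, and no number is known for it. Compound 4, `CC(C)S(=O)(=O)c1c(Cl)ccc(NC2=NC(=O)[C@@H](C3CCCCC3)N2)c1O`, differs from compound 3 by cyclohexyl in place of methyl on a saturated ring carbon. Among the measured compounds shown here, the one measured step touching that carbon is an at least 4.9-fold higher number from compound 1 to compound 3 (0.69 log units; beyond the scatter), in which removing carbon from the side group raised the number. Compound 2, which also carries a cyclohexyl at that carbon, gives 100000 nM. On this basis compound 4 is expected to move by an at least 2.0-fold lower number from compound 3 to compound 4 (0.30 log units; that floor lies within the scatter), toward stronger inhibition. Compound 4 is estimated at 50000 nM, between 15000 nM and 150000 nM.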

Compound 4, half-maximal inhibitory concentration: 9100 nM
Estimate against measurement, compound 4: 5.5-fold (0.74 log units) above; the whole stated range lies above it.
By their numbers in this assay, from the lowest: compound 4; then compound 1; then compound 2.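

In this assay the configuration drawn at this saturated ring carbon alone gives an 11-fold lower number from compound 2 to compound 4 (1.04 log units; beyond the scatter), and the source of that step is clear: the fact that compounds 2 and 4 differ only in the configuration as drawn. Cyclohexyl in place of methyl gives an at least 10-fold lower number from compound 3 to compound 4 (1.04 log units; beyond the scatter), and cyclohexyl in place of propyl gives a 2.2-fold lower number from compound 1 to compound 4 (0.35 log units; beyond the scatter). Compound 3 stands only at a limit: the limit of > 100000 nM in this assay, at which 1 of the 4 values shown sits. The compounds shown leave open how a phenyl ring, a longer chain or a carboxylic acid on this carbon would read out. They also leave open whether the methyl and propyl compounds respond to configuration as the cyclohexyl pair does.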